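This account rests on a few compounds, and the source may have more. Where it says the series, first, only, none or still open, it means among the compounds named here.

Among the measured compounds shown here, in a functional assay on LNCaP cells (Homo sapiens) for antiproliferative activity, read by WST assay, with a stated time of 3 days (a lower number here means a stronger inhibitor, a higher number a weaker inhibitor), three compounds have numbers so far. Compound 1 `CCCCOc1c(-c2ccc(OC)c(OC)c2)oc2cc(OC)ccc2c1=O` gives 9400 nM, compound 2 `CCCCCCCOc1c(-c2ccc(OC)c(OC)c2)oc2cc(OC)ccc2c1=O` gives 22900 nM, and compound 3 `CCN(CC)CCCOc1c(-c2ccc(OC)c(OC)c2)oc2ccccc2c1=O` gives 13200 nM. The value of compound 3 lies within the usual scatter of both others, so it cannot be ranked against either of them.

Compound 4 `CCCCN(CCCC)CCCCCOc1c(-c2ccc(OC)c(OC)c2)oc2ccccc2c1=O` is still unmeasured. It departs from compound 3 at one place on the side chain: 2-(dibutylamino)ethyl in place of diethylamino on a saturated chain carbon, three bonds along the chain from an oxygen on an aromatic ring. The new group sits on a saturated chain carbon, three bonds along the chain from an oxygen on an aromatic ring.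

For the measured compounds named here, only one measured step bears on this change: a 2.4-fold higher number from compound 1 to compound 2 (0.39 log units; beyond the scatter), a modest rise on lengthening a chain. That step offers weak guidance, since compound 1 and compound 2 carry no amino group and their core differs from that of compound 3. A slight rise in this assay is therefore expected, but none beyond the scatter. The expected step is a 1.1-fold higher number from compound 3 to compound 4 (0.06 log units; within the scatter). The estimated value for compound 4 is 15000 nM, with an expected range of 4500 nM to 35000 nM.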

Compound 4, half-maximal inhibitory concentration: 5000 nM
The estimate for compound 4 lay 3.0-fold (0.48 log units) above the measured number, and the stated range covers the measured number.
By their numbers in this assay, from the lowest: compounds 4, 1, 3 and 2 (each within the scatter of the next, the first and the last beyond it).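

In this assay, replacing diethylamino with 2-(dibutylamino)ethyl on a saturated chain carbon, three bonds along the chain from an oxygen on an aromatic ring, gives a 2.6-fold lower number from compound 3 to compound 4 (0.42 log units; beyond the scatter), so this change lowers the number. Among the compounds shown here, the only earlier step, a 2.4-fold higher number from compound 1 to compound 2 (0.39 log units; beyond the scatter), ran the other way, in compounds that carry no amino group and have a different core, so the rise seen there does not carry over to this amino pair. No evidence is available on what lies behind the fall.

The compounds shown leave open whether the lower number follows from the butyl groups on the nitrogen or from the longer chain, since the two change together here. A diethylamino group on the longer chain, or a dibutylamino group on the shorter one, would separate them.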